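Cyclohexyl to benzyl on the ester side chain

A few compounds are considered here, and "the series" means these few. Any claim that something is new, unique, unknown or untested is made for them only; others in the source may bear on it.

Measured compounds:
compound 1 `CCCOC(=O)C1=C(C)NC(C)=C(C(=O)OC)C1c1[nH]cnc1Cl`: 437 nM
compound 2 `COC(=O)C1=C(C)NC(C)=C(C(=O)OCC2CCCCC2)C1c1[nH]cnc1Cl`: 355 nM

In an assay on isolated protein for inhibition of Voltage-dependent L-type calcium channel subunit alpha-1C (Cavia porcellus) (on this read-out higher numbers stand for weaker inhibition and lower numbers for stronger inhibition), compound 2 holds the lower of the two numbers recorded so far, but its nearest neighbour is compound 1, and the step of a 1.2-fold lower number from compound 1 to compound 2 (0.09 log units; within the scatter) does not separate the two. Compound 3 `COC(=O)C1=C(C)NC(C)=C(C(=O)OCCc2ccccc2)C1c1[nH]cnc1Cl` shares the core of compound 2 and differs from it in one place: benzyl in place of cyclohexyl on a saturated chain carbon bound to an oxygen next to a carbonyl group. Among the compounds with values here, the only measured step that touches this side chain is the one from compound 1 to compound 2, which swapped one saturated chain group for another without a change beyond the scatter. On that basis the step into compound 3 is expected to be small as well, a 1.2-fold lower number from compound 2 to compound 3 (0.07 log units; within the scatter), with no direction that can be trusted. Compound 3 is therefore estimated at 300 nM in this assay, with a range from 120 nM to 800 nM.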

Compound 3, half-maximal inhibitory concentration: 79.4 nM
Estimate against measurement, compound 3: 3.8-fold (0.58 log units) above; the whole stated range lies above it.
By their numbers in this assay, from the lowest: compound 3; then compounds 2 and 1 (each within the scatter of the next).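

In this assay, the ester side chain proves not to be indifferent to what it carries. Benzyl in place of cyclohexyl gives a 4.5-fold lower number from compound 2 to compound 3 (0.65 log units; beyond the scatter), and phenyl in place of methyl at the chain end gives a 5.5-fold lower number from compound 1 to compound 3 (0.74 log units; beyond the scatter), whereas the earlier change at this place, a 1.2-fold lower number from compound 1 to compound 2 (0.09 log units; within the scatter), did not move the number. Of the three side chains, only the phenethyloxy of compound 3 stands apart, while the cyclohexylmethoxy of compound 2 and the saturated chain of compound 1 remain within the scatter of each other. No supporting data bear on the reason for this difference.

The cyclohexylmethyl to phenethyl change alters both the ring and the number of chain carbons leading to it, and these compounds cannot separate the two. A 2-cyclohexylethyl chain would address that question directly, while a 3-phenylpropyl chain would show whether the trend continues with a longer linker.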